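The source may report more compounds than this note shows. Statements on the series, on what has been measured and on what is new or still open speak of the compounds shown alone.

Measured compounds:
compound 1, `O=C(N/N=C/c1ccccc1F)c1cnccn1`, in an ADME assay on J774 cells (Mus musculus) for cytotoxicity, read by MTT assay, with a stated time of 48 h, tested at 100 ug/mL; on this read-out lower numbers stand for a stronger effect and higher numbers for a weaker effect at the one concentration tested: 100%
compound 2, `O=C(N/N=C/c1cccc(F)c1)c1cnccn1`: 46%
compound 3, `O=C(N/N=C/c1ccccc1Br)c1cnccn1`: 100%

Three compounds were measured in this assay, and one more, compound 4, `O=C(N/N=C/c1cccc(Br)c1)c1cnccn1`, remains to be measured. Compound 1 and compound 3 share a core and differ only by bromo in place of fluoro on an aromatic carbon. The step from compound 1 to compound 3 is no change at the digits printed from compound 1 to compound 3 (within the scatter). Compound 2 has the same atoms as compound 1, joined differently; the difference between the two cores is not broken down here. Its value in this assay stands furthest from the other two, beyond the scatter from both compound 1 and compound 3.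

Compound 4 differs from compound 2 by bromo in place of fluoro on an aromatic carbon. For the measured compounds named here, this is the same kind of change as the one from compound 1 to compound 3, but not the same: there the bromo enters ortho to a large group, whereas here it enters meta to a large group. The expectation for compound 4 rests on the step from compound 1 to compound 3, which is estimated to carry over, because no change at the digits printed from compound 1 to compound 3 (within the scatter) points to little effect of the same kind of change. The step from compound 2 to compound 4 in this assay is therefore expected to be about a number 14 percentage points higher from compound 2 to compound 4 (beyond the scatter). Compound 4 is accordingly expected to give 60% in this assay, with a range from 35% to 100%, wider than usual since the starting point differs.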

Compound 4, a percentage reported as activity, at one concentration (the size of the read-out at that concentration, not a potency): 100%
Beside the measured number, compound 4's estimate is 40 percentage points below it, within the range that was stated.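

In this assay, bromo in place of fluoro on an aromatic carbon, meta to a large group, gives a number 54 percentage points higher from compound 2 to compound 4 (beyond the scatter). This is a large step, and it shows that the effect of this change in the assay did not carry over from the core of compound 1 to the core of compound 2; the step seen on one core could not be relied upon to predict the step on the other: the same change on two cores in this assay, no change at the digits printed (within the scatter) from compound 1 to compound 3 and a number 54 percentage points higher (beyond the scatter) from compound 2 to compound 4, 54 percentage points apart, beyond the scatter of two such steps

For the compounds shown here, the result rests on only two pairs, so it does not show how the same change would behave on any further core, nor does it give a reason for the difference between the two steps.

The compounds shown carry only fluoro or bromo on the six-membered aromatic ring of carbon only, which leaves open how a chloro group, a methoxy group, an amine or a carboxylic acid would read in this assay on either core. With a single concentration tested, they also leave open whether the gap between the two steps would hold at other concentrations.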